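A few compounds are considered here, and "the series" means these few. Any claim that something is new, unique, unknown or untested is made for them only; others in the source may bear on it.

Measured compounds in an assay on CHO-K1 cells for displacement of a labelled ligand from prostaglandin E2 receptor EP1 subtype (Homo sapiens); on this read-out higher numbers stand for weaker inhibition and lower numbers for stronger inhibition:
Compound 1 `CNC(=O)c1cc(C)n(Cc2cc(Cl)ccc2OCc2ccccc2)n1` gives 100 nM
Compound 2 `Cc1cc(C(=O)NC(C)C)nn1Cc1cc(Cl)ccc1OCc1ccccc1` gives 126 nM
Compound 3 `Cc1cc(C(=O)Nc2ccccc2)nn1Cc1cc(Cl)ccc1OCc1ccccc1` gives 39.8 nM

Compound 3 stands at the lowest of these three numbers: the step of a 2.5-fold lower number from compound 1 to compound 3 (0.40 log units; beyond the scatter) and the step of a 3.2-fold lower number from compound 2 to compound 3 (0.50 log units; beyond the scatter) both lie beyond the scatter, while a 1.3-fold higher number from compound 1 to compound 2 (0.10 log units; within the scatter) lies within it. Compound 4 `Cc1cc(C(=O)Nc2ccc(F)cc2)nn1Cc1cc(Cl)ccc1OCc1ccccc1` has not yet been measured. It differs from compound 3 in one place: fluoro in place of hydrogen on an aromatic carbon. The measured steps each exchange the whole group on the amide-type nitrogen; none of them adds a substituent to a phenyl already present, so they bear only loosely on this change. Without a direct precedent, the expected step of a 1.1-fold lower number from compound 3 to compound 4 (0.06 log units; within the scatter) lies within the scatter, with no firm direction. Compound 4 is therefore estimated at 35 nM, within a range from 15 nM to 90 nM.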

Compound 4, half-maximal inhibitory concentration: 79.4 nM
For compound 4 the middle estimate is 2.3-fold (0.36 log units) below the measured one, within the range that was stated.
By their numbers in this assay, from the lowest: compounds 3, 4, 1 and 2 (each within the scatter of the next, the first and the last beyond it).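

In this assay, putting fluoro on the phenyl of the amide, para to a large group, keeps the number within the scatter of the unsubstituted compound (a 2.0-fold higher number from compound 3 to compound 4 (0.30 log units; within the scatter)), so this position accepts a small substituent without a clear loss. Yet 4-fluorophenyl does not stand clear of the smaller amide groups (a 1.3-fold lower number from compound 1 to compound 4 (0.10 log units; within the scatter); a 1.6-fold lower number from compound 2 to compound 4 (0.20 log units; within the scatter)), as phenyl did. Nothing available here gives a cause for this. Still open, going by these compounds, is how a larger or different group at this place, such as chloro, methoxy or an amine, would read, and whether fluoro elsewhere on this ring would read the same.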